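The source may report more compounds than this note shows. Statements on the series, on what has been measured and on what is new or still open speak of the compounds shown alone.

Measured in an ADME assay on RAW264.7 cells (Mus musculus) for cytotoxicity, read by MTT assay, with a stated time of 18 h; a higher number here means that more compound is tolerated, a lower number that less compound is tolerated:
compound 1 `C=C1C(=O)OC[C@@H]1CCOC(=O)Nc1ccc(C(C)C)cc1` gives 15300 nM;
compound 2 `C=C1C(=O)OC[C@H]1CCOC(=O)Nc1ccc(Br)cc1` gives 8470 nM;
compound 3 `C=C1C(=O)OC[C@H]1CCOC(=O)Nc1ccc(C(C)C)cc1` gives 12400 nM.

Going by the values given here, compound 1 stands at one end of these three numbers, yet all three sit within the usual scatter of one another, so no compound can be said to be tolerated better or worse than another. Two steps help to read the shared core. Compound 1 and compound 3 differ only in configuration as drawn (the fact that compounds 1 and 3 differ only in the configuration as drawn), and the step of a 1.2-fold lower number from compound 1 to compound 3 (0.09 log units; within the scatter) is within the scatter. Compound 2 and compound 3 differ in the group on the aromatic carbon, and the step of a 1.5-fold higher number from compound 2 to compound 3 (0.17 log units; within the scatter) is also within the scatter.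

The unmeasured compound 4 `C=C1C(=O)OC[C@@H]1CCOC(=O)Nc1ccc(OC)cc1` differs from compound 1 by methoxy in place of isopropyl on an aromatic carbon. Among the compounds with values here, the change again sits on an aromatic carbon, para to a large group, and the one measured step at that position stayed within the scatter, so no step beyond the scatter is expected in this assay in either direction. The expected step is a 1.2-fold lower number from compound 1 to compound 4 (0.07 log units; within the scatter). For compound 4 the estimate is 13000 nM, ranging from 6000 nM to 28000 nM.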

Compound 4, half-maximal cytotoxic concentration: 11900 nM
Compound 4: the middle estimate sits 1.1-fold (0.04 log units) above what was measured; the range from low to high includes it.
By their numbers in this assay, from the lowest: compounds 2, 4, 3 and 1 (each within the scatter of the next).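

In this assay, methoxy in place of isopropyl gives a 1.3-fold lower number from compound 1 to compound 4 (0.11 log units; within the scatter). This step shows that a group with a hydrogen-bond acceptor and an oxygen on the aromatic carbon, para to a large group, can replace a group of carbon only without leaving the scatter, whereas the earlier step at this position exchanged only bromo and isopropyl, neither of which has that oxygen. With a step this small there is nothing to explain, and nothing at hand speaks to any cause for it.

On these data alone, whether an amine, a carboxylic acid or a longer chain on this aromatic carbon would give a step beyond the scatter remains open. As far as these compounds go, it is also open whether methoxy would give a similar step on the configuration drawn in compound 3.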